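The source may report more compounds than this note shows. Statements on the series, on what has been measured and on what is new or still open speak of the compounds shown alone.

Working notes on the series. Compound 1 `CC(=O)c1ccc(NC(=O)c2nc(-c3ccccc3)n(-c3ccc(S(N)(=O)=O)cc3)n2)cc1` stands highest of the two numbers in a functional assay on the whole organism for inhibition, with Rattus norvegicus as the target, read by paw edema, with stated times of 30 min and 5 h, at a dose of 0.28 mmol/kg by the oral route (on this read-out higher numbers stand for more inhibition at the one dose given (going by the name of the read-out) and lower numbers for less inhibition), where compound 1 gives 42%; compound 2 `NNC(=O)c1nc(-c2ccccc2)n(-c2ccc(S(N)(=O)=O)cc2)n1` gives 32%, and the step of a number 10 percentage points lower from compound 1 to compound 2 (within the scatter) lies within the scatter. Compound 3 `COC(=O)c1nc(-c2ccccc2)n(-c2ccc(S(N)(=O)=O)cc2)n1` is still to be measured. It differs from compound 1 by methoxy in place of (4-acetylphenyl)amino on a carbonyl carbon. Within the data shown here, the only step with a bearing is the one on the same carbonyl carbon, where amino in place of 4-acetylphenyl on an amide-type nitrogen gave a number 10 percentage points lower from compound 1 to compound 2 (within the scatter); a step of like size or none beyond the scatter is expected here, so compound 3 is estimated at 32% (range 18% to 46%), a step of a number 10 percentage points lower from compound 1 to compound 3 (within the scatter).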

Compound 3, a percentage reported as inhibition, in the whole organism at one dose (the size of the read-out at that dose, not a potency): 46%
Beside the measured number, compound 3's estimate is 14 percentage points below it; the range from low to high includes it.
By their numbers in this assay, from the lowest: compounds 2, 1 and 3 (each within the scatter of the next, the first and the last beyond it).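

In this assay, the whole (4-acetylphenyl)amino group, ring included, is replaced by methoxy on the carbonyl carbon without a step beyond the scatter (a number 4 percentage points higher from compound 1 to compound 3 (within the scatter)). Among these compounds, the same methoxy in place of aminoamino gives the first step beyond the scatter at this position, though a modest one (a number 14 percentage points higher from compound 2 to compound 3 (beyond the scatter)), so the number does respond to the group on this carbonyl carbon. Nothing measured explains either step. The compounds shown leave open how a carboxylic acid, an ethoxy group or a longer alkoxy chain on this carbonyl carbon would read.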